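The source may report more compounds than this note shows. Statements on the series, on what has been measured and on what is new or still open speak of the compounds shown alone.

Compound 3 `NS(=O)(=O)c1ccc(N2N=C(c3ccc(Oc4ccccc4)cc3)CC2c2cccc(Cl)c2)cc1` gives 9000 nM in an ADME assay on BHK-21 cells (Mesocricetus auratus) for cytotoxicity, read by MTT assay, with a stated time of 72 h; on this read-out lower numbers stand for higher toxicity in this test and higher numbers for lower toxicity in this test. Compound 1 `Cc1cccc(C2CC(c3ccc(Oc4ccccc4)cc3)=NN2c2ccc(S(N)(=O)=O)cc2)c1` gives 8000 nM and compound 2 `NS(=O)(=O)c1ccc(N2N=C(c3ccc(Oc4ccccc4)cc3)CC2c2ccc(Cl)cc2)cc1` gives 7000 nM; all three values lie inside the usual scatter of one another, with a 1.1-fold higher number from compound 1 to compound 3 (0.05 log units; within the scatter), a 1.3-fold higher number from compound 2 to compound 3 (0.11 log units; within the scatter) and a 1.1-fold lower number from compound 1 to compound 2 (0.06 log units; within the scatter). Compound 4 `NS(=O)(=O)c1ccc(N2N=C(c3ccc(Oc4ccccc4)cc3)CC2c2cccc(F)c2)cc1` carries fluoro in place of chloro on an aromatic carbon. Among the compounds with values here, the closest precedent is the exchange at the same aromatic carbon, a 1.1-fold higher number from compound 1 to compound 3 (0.05 log units; within the scatter), which stayed inside the scatter, as did exchange of 4-chlorophenyl for 3-chlorophenyl, a 1.3-fold higher number from compound 2 to compound 3 (0.11 log units; within the scatter). Nothing among these compounds separates substituents on that ring, so for compound 4 in this assay no step beyond the scatter is expected: no change at the digits printed from compound 3 to compound 4 (within the scatter). Compound 4 is estimated at 9000 nM, with a range from 5000 nM to 16000 nM.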

Compound 4, half-maximal cytotoxic concentration: 10000 nM
Beside the measured number, compound 4's estimate is 1.1-fold (0.05 log units) below it; measured number inside the range.
By their numbers in this assay, from the lowest: compounds 2, 1, 3 and 4 (each within the scatter of the next).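

In this assay fluoro on this aromatic carbon does not separate from chloro, with a 1.1-fold higher number from compound 3 to compound 4 (0.05 log units; within the scatter) as the step, or from methyl, with a 1.3-fold higher number from compound 1 to compound 4 (0.10 log units; within the scatter) as the step. The exchange of 4-chlorophenyl for 3-fluorophenyl, with a 1.4-fold higher number from compound 2 to compound 4 (0.15 log units; within the scatter) as the step, also stays inside the scatter. No measurement at hand offers an explanation for these results. Still open, from the compounds shown here alone, is whether an amine or a carboxylic acid on this ring would give a step beyond the scatter. Also open, going by these compounds, is whether any exchange elsewhere on the shared core would do so.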